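Notes on the step from compound 3 to compound 4

The source may hold more compounds than are shown below. What is called first, only, known or untested is meant among the compounds shown, and "the series" means these compounds.

Measured in an ADME assay (liver) for metabolic stability, with Liver microsome (Homo sapiens) as the target, read by LC-MS, using microsomes, with a stated time of 30 min, tested at 4 uM (on this read-out lower numbers stand for a less stable compound and higher numbers for a more stable compound), so far
compound 1 `CCN1CCN(c2nc(C)nc3c2nc(-c2ccccc2Cl)n3C)CC1` gives 7%
compound 2 `CCN1CCN(c2nc(C)nc3c2nc(-c2ccccc2Cl)n3CCOC)CC1` gives 31%
compound 3 `COc1cccc(-c2nc3c(N4CCN(C)CC4)nc(C)nc3n2C2CCOCC2)c1` gives 40%

Compound 3 stands above compound 1 by more than the scatter, while its gap to compound 2 lies within the scatter. Compound 4 `COc1ccc(-c2nc3c(N4CCN(C)CC4)nc(C)nc3n2C2CCOCC2)c(C)c1` is still unmeasured. It carries 4-methoxy-2-methylphenyl in place of 3-methoxyphenyl on an aromatic carbon and is otherwise the same as compound 3.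

Among the measured compounds shown here, the only measured single-place change is a number 24 percentage points higher from compound 1 to compound 2 (beyond the scatter), a modest step beyond the scatter. That change lies on a saturated chain, not on this aromatic group, so it shows only that this assay can respond to one change in the series. For the measured compounds named here, no measured step gives a size or direction for the present swap, so no step beyond the scatter is expected. The expected change is a number 4 percentage points lower from compound 3 to compound 4 (within the scatter) and the wide range reflects that gap in the data. The starting point is compound 3 at 40% as the closest measured structure. For compound 4 the estimated value is 36% with an expected range of 15% to 57%.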

Compound 4, percent of the compound remaining: 21%
The estimate for compound 4 lay 15 percentage points above the measured number; low and high end bracket the measured number.
By their numbers in this assay, from the lowest: compound 1; then compounds 4, 2 and 3 (each within the scatter of the next, the first and the last beyond it).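

Among the compounds shown here, the step in this assay for 4-methoxy-2-methylphenyl in place of 3-methoxyphenyl is a number 19 percentage points lower from compound 3 to compound 4 (beyond the scatter) and is the first measured change on this aromatic group. The aromatic carbon between two ring nitrogen atoms is therefore a second place in the series where one change moves the number beyond the scatter, the first being the saturated chain of the earlier step. Nothing available explains the lower number, and the methoxy shift and the added methyl arrive together in this one step.

Which of those two differences carries the step stays open, and 4-methoxyphenyl or 2-methylphenyl at this place would separate them. Equally open, as far as these compounds go, is whether a step of this size would persist with a longer chain in place of the oxan-4-yl group.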